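This account rests on a few compounds, and the source may have more. Where it says the series, first, only, none or still open, it means among the compounds named here.

Compound 1 `CCCCc1nc(=O)c(S(=O)(=O)c2ccc(-n3ccccc3=O)cc2)c(O)n1-c1c(OC)cccc1OC`: 63%
Compound 2 `CCCCc1[nH]c(=O)c(S(=O)(=O)c2ccc(-n3cc(Cl)ccc3=O)cc2)c(O)c1-c1c(OC)cccc1OC`: 64%
Compound 3 `COc1cccc(OC)c1-n1c(COC(C)C)nc(=O)c(S(=O)(=O)c2ccc(-c3ccc(F)nc3)cc2)c1O`: 90%

In an ADME assay on microsomes from liver (Mus musculus) for metabolic stability, using NADPH, with a stated time of 10 min (on this read-out lower numbers stand for a less stable compound and higher numbers for a more stable compound), compound 1 gives 63%. That is within the scatter of compound 2 and beyond the scatter below compound 3. Compound 4 `CCCCc1nc(=O)c(S(=O)(=O)c2ccc(C3CC3)cc2)c(O)n1-c1c(OC)cccc1OC` has not yet been measured. It keeps the core of compound 1 but makes one change on an aromatic carbon, para to a large group: a group of 3 heavy atoms (3 carbon; one three-membered non-aromatic ring of carbon only) in place of a group of 7 heavy atoms (5 carbon, 1 nitrogen, 1 oxygen; one six-membered aromatic ring with 1 hetero atom), on an aromatic carbon. For the measured compounds named here, no measured pair shows this change directly. Going by the values given here, the only guide is that the butyl chain stays, and compound 2, which carries it too, gives 64%. The expected a number 2 percentage points higher from compound 1 to compound 4 (within the scatter) stays within the scatter, so no clear move in either direction is anticipated. For compound 4 the estimated value is 65%, with an expected range of 46% to 83%.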

Compound 4, percent of the compound remaining: 93%
Compound 4: middle estimate off by 28 percentage points, on the low side, outside the stated range (above it).
By their numbers in this assay, from the lowest: compounds 1 and 2 (each within the scatter of the next); then compounds 3 and 4 (each within the scatter of the next).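

For the compounds shown here, this gives the first direct look at this position: in this assay, cyclopropyl in place of the group carrying a six-membered aromatic ring with 1 hetero atom, on the aromatic carbon para to a large group, gives a number 30 percentage points higher from compound 1 to compound 4 (beyond the scatter) with the butyl chain kept. The group on this carbon therefore matters for this read-out, even with the rest of the core of compound 1 unchanged.

On these data alone, what a methyl group or an amine on this carbon would give stays open, as does the effect of cyclopropyl alongside a chain other than butyl. Nothing shown here gives a reason for the rise.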